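The compounds below may be only part of what the source reports. "The series", "measured", "known", "first", "only" and "open" are said of these compounds alone.

Measured compounds:
Compound 1, `COc1ccccc1NC1=CC(=O)c2c(nc3n2[C@H]2OC[C@@H](O)[C@H]2OC3)C1=O`, in a functional assay on ECa-109 cells for inhibition, with ECa-109 cell line (Homo sapiens) as the target, read by sulforhodamine B assay (on this read-out lower numbers stand for stronger inhibition and higher numbers for weaker inhibition), gives > 4000 nM, a limit of the assay.
Compound 2, `Cc1ccc(NC2=CC(=O)c3c(nc4n3[C@H]3OC[C@@H](O)[C@H]3OC4)C2=O)cc1`, in this assay gives > 4000 nM, also a limit.
Compound 3, `O=C1C=C(Nc2cccc(Cl)c2)C(=O)c2c1nc1n2[C@H]2OC[C@@H](O)[C@H]2OC1`, in this assay gives 4690 nM.

Among the measured compounds shown here, compound 3 thus supplies the only number among the three values; the other two sit at the limit of > 4000 nM in this assay, at which 2 of the 3 values shown sit. For the measured compounds named here, the single step between measured compounds, a step that the two limits leave unreadable from compound 1 to compound 2, is unreadable, both of its ends being limits.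

Compound 4, `O=C1C=C(N2CCC2)C(=O)c2c1nc1n2[C@H]2OC[C@@H](O)[C@H]2OC1`, differs from compound 3 by azetidin-1-yl in place of (3-chlorophenyl)amino on a double-bonded ring carbon. Going by the values given here, none of the measured compounds carries an azetidin-1-yl group, so no measured step bears on this change. Compound 4 is therefore expected to stay near compound 3, with a 1.3-fold higher number from compound 3 to compound 4 (0.11 log units; within the scatter) expected to fall within the scatter. For compound 4 the estimate in this assay is 6000 nM, in the range 1500 nM to 30000 nM.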

Compound 4, half-maximal inhibitory concentration: > 16000 nM
Compound 4: no number, only a limit; the forecaster's own chance of this, stated with the estimate: 55%; at least 2.6-fold (0.42 log units) between middle value and limit.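

In this assay, among the compounds shown here, azetidin-1-yl in place of (3-chlorophenyl)amino on the double-bonded ring carbon gives an at least 3.4-fold higher number from compound 3 to compound 4 (0.53 log units; beyond the scatter), the first step here that can be read, since the step between compound 1 and compound 2 cannot. Compound 4 gives > 16000 nM, which is a limit of the assay. For the compounds shown here, the read-out therefore responds to the group at this position, an effect the earlier compounds could not show.

The change removes the aromatic ring and the hydrogen-bond donor together, leaving their separate contributions open. Also open, going by these compounds, is how a benzylamino group or a morpholine ring at this position would read.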